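Trifluoromethyl to Trifluoromethoxy: Expected Maximal Response

This account rests on a few compounds, and the source may have more. Where it says the series, first, only, none or still open, it means among the compounds named here.

Of the compounds shown here, two have been measured. Compound 1 `O=C(CN1CCC(c2cccc[n+]2[O-])CC1)Nc1cccc(F)c1` gives 70% in a functional assay on HEK293 cells for agonist activity at D(4) dopamine receptor (Homo sapiens), read by FLIPR (on this read-out higher numbers stand for larger maximal responses and lower numbers for smaller maximal responses), and compound 2 `O=C(CN1CCC(c2cccc[n+]2[O-])CC1)Nc1cccc(C(F)(F)F)c1` gives 75%. For the measured compounds named here, the step of a number 5 percentage points higher from compound 1 to compound 2 (within the scatter) is the only measured step; compound 2 stands at the higher of the two numbers, though the gap to compound 1 lies within the scatter, so no order between them can be claimed.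

Compound 3 `O=C(CN1CCC(c2cccc[n+]2[O-])CC1)Nc1cccc(OC(F)(F)F)c1` differs from compound 2 by trifluoromethoxy in place of trifluoromethyl on an aromatic carbon. Going by the values given here, no measured step bears directly on this change; the one measured step, a number 5 percentage points higher from compound 1 to compound 2 (within the scatter), changed the same position and stayed within the scatter. Compound 3 is therefore expected to show a step of a number 2 percentage points lower from compound 2 to compound 3 (within the scatter), that is, none beyond the scatter. The estimate for compound 3 in this assay is 73%, with a range from 58% to 88%.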

Compound 3, largest response reached (reported as efficacy), in percent of the reference or control that the assay uses: 51%
Beside the measured number, compound 3's estimate is 22 percentage points above it; measured number below the stated range.
By their numbers in this assay, from the lowest: compound 3; then compounds 1 and 2 (each within the scatter of the next).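

At this aromatic carbon, in this assay, the choice of group does make a difference: the step is a number 24 percentage points lower from compound 2 to compound 3 (beyond the scatter), and against the fluoro group it is a number 19 percentage points lower from compound 1 to compound 3 (beyond the scatter). The earlier step, a number 5 percentage points higher from compound 1 to compound 2 (within the scatter), gave no sign of this, so the position tolerated fluoro and trifluoromethyl alike but sets trifluoromethoxy apart from both. The change adds one oxygen, counted as a hydrogen-bond acceptor, to the group that leaves, but nothing at hand ties the lower response to that oxygen or to anything else.

Going by these compounds, whether a methoxy group, a nitrile or an amine at this carbon would stay level with compound 1 and compound 2 or fall towards compound 3 remains open. So does whether trifluoromethoxy would lower the response in the same way elsewhere on this ring.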